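The compounds below may be only part of what the source reports. "The series", "measured", "known", "first", "only" and "open" are said of these compounds alone.

Series notes. Compound 1 `O=C(Nc1cccc(C(F)(F)F)c1)N[C@H]1CC[C@@H](Oc2ccc(F)cc2)CC1` is the reference: in a functional assay on CRL2813 cells (Homo sapiens) for cytotoxicity, read by sulforhodamine B assay, with a stated time of 5 days (a lower number here means a stronger inhibitor, a higher number a weaker inhibitor), compound 1 gives 2600 nM. Compound 2 `O=C(Nc1ccccc1C(=O)O)N[C@H]1CC[C@@H](Oc2ccc(F)cc2)CC1` carries a carboxylic acid on the aryl urea ring; in this assay compound 2 returns only a limit, > 20000 nM, which is the limit of > 20000 nM in this assay, at which 1 of the 3 values shown sits, and not a number. Compound 3 `COc1cccc(NC(=O)N[C@H]2CC[C@H](Oc3ccc(F)cc3)CC2)c1` carries a 3-methoxyphenyl on the urea nitrogen; in this assay compound 3 gives 14000 nM, the highest of the two numbers on hand, with compound 1 as the nearest number and that gap beyond the scatter.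

Compound 4 `O=C(Nc1ccccc1F)N[C@H]1CC[C@H](Oc2ccc(F)cc2)CC1` is not yet measured. Against compound 3 the change is 2-fluorophenyl in place of 3-methoxyphenyl on an amide-type nitrogen. Going by the values given here, no measured pair isolates this change. Compound 1 and compound 3 differ in the substituent on the same ring and their values sit apart by more than the scatter, so the substituent on this ring does move the number, though the acid of compound 2 shows that not every substituent keeps a measurable value. The step from compound 3 to compound 4 is expected to be modest, more likely toward a lower number than a higher one, roughly a 1.6-fold lower number from compound 3 to compound 4 (0.19 log units; within the scatter). Compound 4 is therefore estimated at 9000 nM, with a plausible range from 3000 nM to 25000 nM.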

Compound 4, half-maximal inhibitory concentration: 17500 nM
Estimate against measurement, compound 4: 1.9-fold (0.29 log units) below; the measured number falls inside the stated range.
By their numbers in this assay, from the lowest: compound 1; then compounds 3 and 4 (each within the scatter of the next). At a limit, above all of these: compound 2.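

In this assay, going by these compounds alone, 2-fluorophenyl in place of 3-methoxyphenyl on the amide-type nitrogen gives a 1.3-fold higher number from compound 3 to compound 4 (0.10 log units; within the scatter), the first step that isolates a single change. The number therefore does not separate these two aryl groups, even though the exchange swaps a methoxy group for a fluorine and the substituent's place on the phenyl ring differs between the two names. Nothing on hand gives a reason for this step.

From the compounds shown here alone, compounds 1 and 2 differ from compounds 3 and 4 both in the aryl group and in the stereochemistry drawn on the core, so it remains open how much of their values belongs to either difference. Also open, going by these compounds, are how a phenyl ring carrying an amine or a nitrile would read on this nitrogen, and whether 2-fluorophenyl and 3-methoxyphenyl would stay level with each other under the stereochemistry of compound 1.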